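Aryl ester series on the shared core: antiproliferative read-out

The compounds below may be only part of what the source reports. "The series", "measured", "known", "first", "only" and "open" are said of these compounds alone.

Three esters have been measured in a functional assay on K562 cells (Homo sapiens) for antiproliferative activity, read by sulforhodamine B assay, with a stated time of 48 h, tested at 50 uM; a lower number here means less inhibition, a higher number more inhibition at the concentration tested (going by the name of the read-out). Compound 1 `CC1=CC[C@H](C(C)C)c2cc(C)c(OC(=O)c3cccc(C(F)(F)F)c3)cc21`, carrying a trifluoromethylphenyl ester, gives 45.5%. Compound 3 `Cc1cc2c(C(C)C)ccc(C)c2cc1OC(=O)c1ccc([N+](=O)[O-])cc1`, a nitrophenyl ester on a related aromatic core, gives 100%. Compound 2 `CC1=CC[C@H](C(C)C)c2cc(C)c(OC(=O)c3cccc(Cl)c3)cc21`, the 3-chlorophenyl ester, is reported in this assay only as "not active" (no number reported), with no number attached, so it stands below the two numbered compounds without a measured value of its own.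

Compound 4 `CC1=CC[C@H](C(C)C)c2cc(C)c(OC(=O)c3ccc(C)cc3)cc21` is not yet measured. Relative to compound 2 the change is 4-methylphenyl in place of 3-chlorophenyl on a carbonyl carbon. For the measured compounds named here, with no measured step available between these two, the size of the expected change is uncertain; what the data show is that compound 2 is reported as not active while compound 1, another substituted phenyl ester on the same core, gives 45.5%. Compound 4 is therefore expected to give a low inhibition in this assay, estimated at 20% with a range from 0% to 45%, and a fair chance that it, like compound 2, is reported as not active.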

Compound 4, a percentage reported as inhibition, at one concentration (the size of the read-out at that concentration, not a potency): 100%
Estimate against measurement, compound 4: 80 percentage points below; measured number outside the range, above it.
By their numbers in this assay, from the lowest: compound 1; then compounds 3 and 4 (each within the scatter of the next).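

For the compounds shown here, compound 2 has no number in this assay and compound 4 gives 100%, so no step between them can be read. The compounds shown leave open how the substituent on the phenyl ester relates to the read-out on the shared core. No evidence on hand bears on this result.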